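This account rests on a few compounds, and the source may have more. Where it says the series, first, only, none or still open, it means among the compounds named here.

Measured so far:
compound 1 `CC(C)(C)c1ccc(C(=O)NCc2ccc(NS(C)(=O)=O)cc2F)cc1`: 47 mL.min-1.g-1
compound 2 `CS(=O)(=O)Nc1ccc(CNC(=O)c2ccc(N3CCC3)cc2)c(Cl)c1`: 8.6 mL.min-1.g-1

In an ADME assay on microsomes from liver (Rattus norvegicus, strain Sprague-Dawley) for metabolic stability, read by HPLC, using NADPH, with stated times of 5 min and 60 min, tested at 10 uM (a higher number here means faster removal of the compound, a lower number slower removal), compound 1 gives 47 mL.min-1.g-1. In this assay compound 2 gives 8.6 mL.min-1.g-1, the lower of the two numbers, and the gap to compound 1 lies beyond the usual scatter of this assay. Compound 3 `CS(=O)(=O)Nc1ccc(CNC(=O)c2ccc(C(F)(F)C(F)(F)F)cc2)c(Cl)c1` has not yet been measured in this assay. It differs from compound 2 in one place: 1,1,2,2,2-pentafluoroethyl in place of azetidin-1-yl on an aromatic carbon. Among the measured compounds shown here, no pair of measured compounds shows this same change, so any expectation rests on where compound 2 stands on its own. The reviewer expects the step of a 1.7-fold higher number from compound 2 to compound 3 (0.24 log units; within the scatter) to be a modest rise in clearance, and it may well be no larger than the scatter. For compound 3 in this assay the estimated value is 15 mL.min-1.g-1, with a likely range from 5 mL.min-1.g-1 to 45 mL.min-1.g-1.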

Compound 3, intrinsic clearance in microsomes: 14 mL.min-1.g-1
Compound 3: middle estimate off by 1.1-fold (0.03 log units), on the high side; low and high end bracket the measured number.
By their numbers in this assay, from the lowest: compounds 2 and 3 (each within the scatter of the next); then compound 1.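

In this assay, 1,1,2,2,2-pentafluoroethyl in place of azetidin-1-yl on an aromatic carbon, para to a large group, gives a 1.6-fold higher number from compound 2 to compound 3 (0.21 log units; within the scatter). The change is a wide one in what is counted: a four-membered ring with a nitrogen and a hydrogen-bond acceptor leaves, and an open chain of carbon and fluorine with more heavy atoms and no hydrogen-bond acceptor enters. Even so, the read-out does not move beyond the scatter, so at this position the ring and its nitrogen are not required for a number in this range.

On these data alone, whether that holds for a trifluoromethyl, a nitrile, a piperidine or a carboxylic acid at the same place remains open. What lies behind the result is also unsettled, as no measurement shown here bears on it.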